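Swapping the ring on the amide nitrogen

The source may hold more compounds than are shown below. What is called first, only, known or untested is meant among the compounds shown, and "the series" means these compounds.

Among the measured compounds shown here, compound 2 `O=C(Nc1ccc(Cl)nc1)C1CCCN(C(=O)c2cc(C(F)(F)F)cc(C(F)(F)F)c2)C1` gives 25% in an ADME assay on PC-3 cells (Homo sapiens) for cytotoxicity, read by WST assay, tested at 100 uM (on this read-out higher numbers stand for more inhibition at the one concentration tested (going by the name of the read-out) and lower numbers for less inhibition), the higher of the two numbers measured so far; compound 1 `Cc1nc(-c2cccc(NC(=O)C3CCCN(C(=O)c4cc(C(F)(F)F)cc(C(F)(F)F)c4)C3)c2)cs1` gives 1%. Compound 3 `CSc1cccc(NC(=O)C2CCCN(C(=O)c3cc(C(F)(F)F)cc(C(F)(F)F)c3)C2)c1` differs from compound 2 in one place: 3-(methylsulfanyl)phenyl in place of 6-chloropyridin-3-yl on an amide-type nitrogen. For the measured compounds named here, the only measured step touching this position is a number 24 percentage points higher from compound 1 to compound 2 (beyond the scatter), so the ring on the amide nitrogen can shift the read-out modestly. Compound 3 again carries a ring of carbon only, and a drop is expected because compound 1 gives 1%, roughly a number 15 percentage points lower from compound 2 to compound 3 (beyond the scatter). Compound 3 is therefore estimated at 10%, between 0% and 35%.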

Compound 3, a percentage reported as inhibition, at one concentration (the size of the read-out at that concentration, not a potency): 0%
For compound 3 the middle estimate is 10 percentage points above the measured one; measured number inside the range.
By their numbers in this assay, from the lowest: compounds 3 and 1 (each within the scatter of the next); then compound 2.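

Among the compounds shown here, with this second phenyl ring, the change at the amide nitrogen is a number 25 percentage points lower from compound 2 to compound 3 (beyond the scatter), so the higher number so far belongs only to the 6-chloropyridin-3-yl ring. Methylsulfanyl in place of 2-methyl-1,3-thiazol-4-yl on the phenyl ring gives a number 1 percentage points lower from compound 1 to compound 3 (within the scatter), so these two groups cannot be told apart here. Nothing available explains the gap between the rings.

Going by these compounds, it remains open whether the chlorine or the ring nitrogen of compound 2 matters more. On these data alone, how a phenyl ring carrying an amine or a carboxylic acid would read also remains open.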